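The source may report more compounds than this note shows. Statements on the series, on what has been measured and on what is new or still open speak of the compounds shown alone.

Of the compounds shown here, three sharing one core have been measured in a functional assay on CHO cells with adenosine receptor A1 (Homo sapiens) as the target, read by cAMP accumulation and immunoassay, with a stated time of 6 min, tested at 1 uM; on this read-out lower numbers stand for a stronger effect and higher numbers for a weaker effect at the one concentration tested. Compound 1, `Nc1scc(CN2CCN(c3cc(Cl)cc(Cl)c3)CC2)c1C(=O)c1ccc(Cl)cc1`, gives -69% in this assay. Compound 2, `Nc1scc(CN2CCN(c3ccc(F)cc3F)CC2)c1C(=O)c1ccc(Cl)cc1`, gives -66%. Compound 3, `Nc1scc(CN2CCN(c3ccc(F)c(F)c3)CC2)c1C(=O)c1ccc(Cl)cc1`, gives -78%. On these numbers compound 3 holds the lowest of the three values; its nearest neighbour is compound 1, from which it is separated by a number 9 percentage points lower from compound 1 to compound 3 (within the scatter), and its furthest is compound 2, separated by a number 12 percentage points lower from compound 2 to compound 3 (beyond the scatter). The remaining step, a number 3 percentage points higher from compound 1 to compound 2 (within the scatter), is likewise small.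

Compound 4, `Nc1scc(CN2CCN(c3c(F)cc(F)cc3F)CC2)c1C(=O)c1ccc(Cl)cc1`, differs from compound 3 only at the aryl group on the amine nitrogen in the ring: 2,4,6-trifluorophenyl in place of 3,4-difluorophenyl on an amine nitrogen in a ring. All three measured steps bear on this change, since each of them also swaps one aryl group for another at the same place, and none of them moved the read-out by more than a modest amount. Among the compounds with values here, one step, the one from compound 2 to compound 3, went beyond the scatter, and the new group moves away from the 3,4-difluorophenyl of compound 3, so a small upward drift is possible. The expected step is therefore a number 10 percentage points higher from compound 3 to compound 4 (within the scatter), which is estimated to lie within the scatter. Compound 4 is expected to give about -68% in this assay, in a range from -82% to -54%.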

Compound 4, a percentage reported as activity, at one concentration (the size of the read-out at that concentration, not a potency): -56%
For compound 4 the middle estimate is 12 percentage points below the measured one; low and high end bracket the measured number.
By their numbers in this assay, from the lowest: compounds 3, 1, 2 and 4 (each within the scatter of the next, the first and the last beyond it).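

In this assay, the aryl group on the amine nitrogen in the ring proves able to weaken the read-out well beyond the scatter: 2,4,6-trifluorophenyl in place of 3,4-difluorophenyl gives a number 22 percentage points higher from compound 3 to compound 4 (beyond the scatter), and the same group in place of 3,5-dichlorophenyl gives a number 13 percentage points higher from compound 1 to compound 4 (beyond the scatter). Adding one fluoro to the 2,4-difluorophenyl group gives a number 10 percentage points higher from compound 2 to compound 4 (within the scatter), so that single addition cannot be told apart from repeat variation, and both the 2,4-difluorophenyl and 2,4,6-trifluorophenyl groups stand apart from 3,4-difluorophenyl, the former through a number 12 percentage points lower from compound 2 to compound 3 (beyond the scatter). Nothing in the available data explains these differences at this position.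

The compounds shown leave open whether the read-out at this position follows the number of halogen atoms on the aryl ring or their arrangement, and a fourth aryl pattern alone would not settle it. Also open, going by these compounds, is how an unsubstituted phenyl, a methoxyphenyl or a pyridyl ring would read on the same amine nitrogen, and whether a trifluoromethyl group would fall with the 3,4-difluorophenyl compound or with the 2,4,6-trifluorophenyl one.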